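This account rests on a few compounds, and the source may have more. Where it says the series, first, only, none or still open, it means among the compounds named here.

Among the measured compounds shown here, in a functional assay on MCF7 cells (Homo sapiens) for antiproliferative activity, read by MTT assay, with a stated time of 48 h (on this read-out higher numbers stand for weaker inhibition and lower numbers for stronger inhibition), compound 1 (`C=C(c1ccc2c(c1)C=CC(C)(C)O2)c1ccc(OC)cc1NC(=O)CN`) gives 420 nM and compound 2 (`C=C(c1ccc2c(c1)C=CC(C)(C)O2)c1ccc(OC)cc1NC(=O)CNC`) gives 720 nM so compound 2 stands within the scatter of the only other measured compound. Compound 3 (`C=C(c1ccc2c(c1)C=CC(C)(C)O2)c1ccc(OC)cc1NC(=O)CN(C)C`) differs from compound 2 in one place: methyl in place of hydrogen on an amine nitrogen. For the measured compounds named here, only one measured step bears on this change, the same replacement made on compound 1. Going by the values given here, on the strength of a 1.7-fold higher number from compound 1 to compound 2 (0.23 log units; within the scatter) as the sole precedent, a similarly small rise or none beyond the scatter is expected in this assay (a 1.3-fold higher number from compound 2 to compound 3 (0.10 log units; within the scatter)). The expected value for compound 3 is 900 nM (estimated range 400 nM to 2000 nM).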

Compound 3, half-maximal inhibitory concentration: 940 nM
Compound 3: the middle estimate sits 1.0-fold (0.02 log units) below what was measured; the range from low to high includes it.
By their numbers in this assay, from the lowest: compounds 1, 2 and 3 (each within the scatter of the next, the first and the last beyond it).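

In this assay the second methyl on the amine nitrogen gives a 1.3-fold higher number from compound 2 to compound 3 (0.12 log units; within the scatter) and so stays within the scatter on its own. The two methyl replacements taken together do pass beyond it, with a 2.2-fold higher number from compound 1 to compound 3 (0.35 log units; beyond the scatter) for dimethylamino in place of amino, so inhibition weakens modestly from the primary amine to the tertiary one. No measured evidence accounts for this. Still open, as far as these compounds go, is how this nitrogen responds to larger groups such as ethyl or a pyrrolidine ring, and whether a hydroxyl can replace the amine altogether.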